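The source may report more compounds than this note shows. Statements on the series, on what has been measured and on what is new or still open speak of the compounds shown alone.

Measured compounds:
- compound 1, `CCCN(CC[C@H]1CC[C@H](NC(=O)/C=C/c2ccccc2Cl)CC1)[C@H]1CCc2nc(N)sc2C1`: 1.2 nM
- compound 2, `CCCN(CC[C@H]1CC[C@H](NC(=O)c2cccc(-n3ccnc3)c2)CC1)[C@H]1CCc2nc(N)sc2C1`: 1.1 nM
- compound 3, `CCCN(CC[C@H]1CC[C@H](NC(=O)c2ccc(-n3cccn3)cc2)CC1)[C@H]1CCc2nc(N)sc2C1`: 3 nM

All three were tested in an assay on brain for displacement of a labelled ligand from D(3) dopamine receptor (Rattus norvegicus); on this read-out lower numbers stand for stronger inhibition and higher numbers for weaker inhibition. Among these numbers compound 1 stands second highest; its value and that of compound 2 lie within the scatter of each other, while compound 3 returns a modestly higher number.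

The unmeasured compound 4, `CCCN(CC[C@H]1CC[C@H](NC(=O)c2ccc(-n3cncn3)cc2)CC1)[C@H]1CCc2nc(N)sc2C1`, is reached from compound 1 by one change: 4-(1H-1,2,4-triazol-1-yl)phenyl in place of 2-(2-chlorophenyl)ethenyl on a carbonyl carbon.

Two measured steps start from the same point and swap the same group for an aromatic amide. The swap to a 3-(1H-imidazol-1-yl)phenyl group gave a 1.1-fold lower number from compound 1 to compound 2 (0.04 log units; within the scatter). The swap to a 4-(1H-pyrazol-1-yl)phenyl group gave a 2.5-fold higher number from compound 1 to compound 3 (0.40 log units; beyond the scatter). Compound 3 is the nearest structural neighbour of compound 4, since both carry a five-membered aromatic ring on the phenyl group in the same place, differing only in the number of nitrogen atoms in that ring. The step to compound 4 is therefore expected to resemble the step to compound 3: a modest rise in the number, estimated as a 2.5-fold higher number from compound 1 to compound 4 (0.40 log units; beyond the scatter).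

Compound 4 is expected to give about 3 nM in this assay , with a likely range from 1.2 nM to 7.5 nM.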

Compound 4, inhibition constant: 2.4 nM
The estimate for compound 4 lay 1.3-fold (0.10 log units) above the measured number; low and high end bracket the measured number.
By their numbers in this assay, from the lowest: compounds 2, 1, 4 and 3 (each within the scatter of the next, the first and the last beyond it).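

In this assay, the step to the 4-(1H-1,2,4-triazol-1-yl)phenyl group gives a 2.0-fold higher number from compound 1 to compound 4 (0.30 log units; within the scatter) and so stays within the usual scatter, even though this group brings hydrogen-bond acceptors and the 2-(2-chlorophenyl)ethenyl group it replaces has none. Among these compounds, exchanging 1H-pyrazol-1-yl for 1H-1,2,4-triazol-1-yl on the aromatic carbon gives a 1.3-fold lower number from compound 3 to compound 4 (0.10 log units; within the scatter), so these two rings cannot be told apart on this read-out, a comparison that the earlier compounds could not offer. Against the 3-(1H-imidazol-1-yl)phenyl group, the change gives a 2.2-fold higher number from compound 2 to compound 4 (0.34 log units; beyond the scatter), a modest gap that is beyond the scatter, although this step alters both the ring and where it sits on the phenyl group, so the compounds shown cannot separate those two changes.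

Nothing available here gives a measured reason for any of these differences. Still open is how the number would respond to a different group on the phenyl ring, such as a carboxylic acid or an amine, since every aromatic amide shown carries a five-membered aromatic ring there.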